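The compounds below may be only part of what the source reports. "The series", "measured", "known", "first", "only" and "open" are said of these compounds alone.

Compound 2 `CCCc1nc(-c2ccccc2)c(CNCCCN2CCN(c3ccccc3Cl)CC2)o1` sits second highest of the three numbers recorded in an assay on HEK293 cells for inhibition of Voltage-dependent T-type calcium channel subunit alpha-1G (Homo sapiens), read by fluorescence, tested at 10 uM (a higher number here means more inhibition at the concentration tested (going by the name of the read-out), a lower number less inhibition), giving 64.7%. Compound 3 `CCCc1nc(-c2ccccc2)c(CNCCN2CCN(C(c3ccccc3)c3ccccc3)CC2)o1` gives 71.9% in this assay, a number within the scatter of compound 2, while compound 1 `CCCc1nc(-c2ccccc2)c(CNCCCN2CCN(c3cccc(OC)c3)CC2)o1` gives 36.4%. Going by the values given here, the one measured step, a number 28.3 percentage points higher from compound 1 to compound 2 (beyond the scatter), is the only guide available, and it shows that exchanging the group on that ring nitrogen can move the read-out modestly. Compound 4 `CCCc1nc(-c2ccccc2)c(CNCCCN2CCN(c3ccccc3)CC2)o1` differs from compound 2 by hydrogen in place of chloro on an aromatic carbon. Since the step from compound 1 to compound 2 involved a different exchange, it bears on this one only loosely. The expectation for compound 4 is a modest fall, a number 16.7 percentage points lower from compound 2 to compound 4 (beyond the scatter), giving an estimated 48% with a range from 28% to 66%.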

Compound 4, a percentage reported as inhibition, at one concentration (the size of the read-out at that concentration, not a potency): 43.7%
Compound 4: middle estimate off by 4.3 percentage points, on the high side; the range from low to high includes it.
By their numbers in this assay, from the lowest: compounds 1 and 4 (each within the scatter of the next); then compounds 2 and 3 (each within the scatter of the next).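

Removing the chloro from the aromatic carbon ortho to a large group gives a number 21 percentage points lower from compound 2 to compound 4 (beyond the scatter) in this assay, so this substituent matters at this place. Exchanging 3-methoxyphenyl for phenyl gives a number 7.3 percentage points higher from compound 1 to compound 4 (within the scatter), so only the chloro compound, compound 2, stands apart from compound 4. No evidence accounts for this difference. The compounds shown leave open whether fluoro, bromo or methyl at this same place would match chloro. They also leave open whether chloro would give a similar read-out elsewhere on the ring.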